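This account rests on a few compounds, and the source may have more. Where it says the series, first, only, none or still open, it means among the compounds named here.

Notes on the series

In an ADME assay on a cell-free system (plasma, Homo sapiens) for metabolic stability (a higher number here means that the compound lasts longer, a lower number that the compound disappears faster), compound 1 `C[C@H](NC(=O)[C@H](N)CC(=O)OCc1ccc(F)cc1)C(=O)O` gives 4.33 h. Compound 3 `C[C@H](NC(=O)[C@H](N)CCC(=O)OCc1ccc(F)cc1)C(=O)O` gives 2 h in this assay, and compound 2 `C[C@H](NC(=O)[C@H](N)CCC(=O)OCc1ccc([N+](=O)[O-])cc1)C(=O)O` gives 0.113 h. Among the three measured compounds compound 1 stands highest, with compound 3 nearest and compound 2 furthest from it, both gaps beyond the scatter.

Compound 3 and compound 2 differ in one place, (nitro in place of fluoro on an aromatic carbon). That change made an 18-fold lower number from compound 3 to compound 2 (1.25 log units; beyond the scatter) in this assay, a large step.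

Compound 1 and compound 3 share the same kind of ester and amide arrangement, but the difference between the two cores is not broken down here.

Compound 4 `C[C@H](NC(=O)[C@H](N)CC(=O)OCc1ccc([N+](=O)[O-])cc1)C(=O)O` has not yet been measured in this assay. It differs from compound 1 by nitro in place of fluoro on an aromatic carbon. The place of this change is described in the same words as for the change from compound 3 to compound 2, so it is the same change, made on the core of compound 1 instead of the core of compound 3. This change occurs twice among the compounds shown, once with a measured outcome.

The expectation for compound 4 rests on that single measured pair: a step of a similar size is expected from compound 1 to compound 4, a 17-fold lower number from compound 1 to compound 4 (1.24 log units; beyond the scatter), because of an 18-fold lower number from compound 3 to compound 2 (1.25 log units; beyond the scatter). On that basis compound 4 is estimated to give 0.25 h in this assay, with a plausible range from 0.08 h to 0.8 h.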

Compound 4, half-life: 0.12 h
Estimate against measurement, compound 4: 2.1-fold (0.32 log units) above, and the stated range covers the measured number.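

In this assay, nitro in place of fluoro on an aromatic carbon gives a 36-fold lower number from compound 1 to compound 4 (1.56 log units; beyond the scatter), a large step in the same direction as the one seen earlier on the other core. Set side by side, the two outcomes agree: the same change on two cores in this assay, an 18-fold lower number (1.25 log units; beyond the scatter) from compound 3 to compound 2 and a 36-fold lower number (1.56 log units; beyond the scatter) from compound 1 to compound 4, 2.0-fold (0.31 log units) apart, within the scatter of two such steps. On these two cores the change therefore carries over in direction and, within the scatter, in size, but two cores are a narrow basis: this says nothing about any further core, and the numbers alone do not tell what lies behind the step.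

The compounds shown carry only fluoro or nitro on the aromatic ring, so it stays open where a ring with a methoxy group, a nitrile or only hydrogen in that same place would fall in this assay. Going by these compounds, it also stays open whether the step survives on a core with a longer chain, or with an amide in place of the ester.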